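This account rests on a few compounds, and the source may have more. Where it says the series, first, only, none or still open, it means among the compounds named here.

Measured in a functional assay on HL-60 cells (Homo sapiens) for inhibition, read by resazurin assay, with a stated time of 72 h; a lower number here means a stronger inhibitor, a higher number a weaker inhibitor:
- Compound 1 `COc1ccc(C2C(O)C(=O)N2c2cc(OC)c(OC)c(OC)c2)cc1`: 13 nM
- Compound 2 `COc1ccc(C2C(C3CC3)C(=O)N2c2cc(OC)c(OC)c(OC)c2)cc1`: 156 nM

Of these two, compound 2 holds the higher number, 156 nM, and so is the weaker inhibitor. Compound 3 `COc1ccc(C2CC(=O)N2c2cc(OC)c(OC)c(OC)c2)cc1` has not yet been measured. It differs from compound 2 by hydrogen in place of cyclopropyl on a saturated ring carbon, which is hydrogen in place of cyclopropyl on a saturated ring carbon. For the measured compounds named here, only one measured step bears on this change: a 12-fold higher number from compound 1 to compound 2 (1.08 log units; beyond the scatter). That large step put cyclopropyl in place of hydroxy on the same ring carbon. Going by the values given here, no measured compound carries hydrogen there, so the step gives only loose guidance. A moderate move to a lower number is therefore expected in this assay, probably not reaching the value of compound 1. The expected change is a 2.2-fold lower number from compound 2 to compound 3 (0.35 log units; beyond the scatter). For compound 3 the estimated value is 70 nM, within an expected range of 20 nM to 300 nM.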

Compound 3, half-maximal inhibitory concentration: 76 nM
Estimate against measurement, compound 3: 1.1-fold (0.04 log units) below; measured number inside the range.
By their numbers in this assay, from the lowest: compound 1; then compound 3; then compound 2.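

With hydrogen on the saturated ring carbon, this position now has a plain reference point in this assay, and the two other groups fall on opposite sides of it. Hydrogen in place of cyclopropyl gives a 2.1-fold lower number from compound 2 to compound 3 (0.31 log units; beyond the scatter) and so a modest gain, while hydrogen in place of hydroxy gives a 5.8-fold higher number from compound 1 to compound 3 (0.77 log units; beyond the scatter) and so a modest loss. Among these three compounds, then, hydroxy is the only group here that goes with a lower number than hydrogen, and nothing at hand explains why these groups rank in this order.

On these data alone, it remains open whether an amine or a fluorine on this ring carbon would come closer to compound 1 or to compound 3. As far as these compounds go, it is equally open whether a methyl group or a longer chain would track cyclopropyl.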